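Trading dichlorophenyl for trifluoromethoxyphenyl on a ghrelin receptor inhibitor

The source may hold more compounds than are shown below. What is called first, only, known or untested is meant among the compounds shown, and "the series" means these compounds.

Measured so far:
Compound 1, `CC(C)(N)C(=O)N[C@H](COCc1cccc(Cl)c1)c1nnnn1CCOC(=O)NCCCCO`: 1.6 nM
Compound 2, `CC(C)(N)C(=O)N[C@H](COCc1cccc(Cl)c1Cl)c1nnnn1CCOC(=O)NCCCCO`: 0.61 nM
Compound 3, `CC(C)(N)C(=O)N[C@H](COCc1cc(C(F)(F)F)cc(C(F)(F)F)c1)c1nnnn1CCOC(=O)NCCCCO`: 34 nM

All three were tested in a functional assay on cells for inhibition of growth hormone secretagogue receptor type 1 (Homo sapiens), read by FLIPR and calcium flux; on this read-out lower numbers stand for an effect already at smaller amounts and higher numbers for an effect only at larger amounts of compound. Compound 2 gives the lowest number of the three; compound 1 is nearest to it, while compound 3 gives a far higher number than compound 2 and lies well beyond the usual scatter from both.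

The unmeasured compound 4, `CC(C)(N)C(=O)N[C@H](COCc1ccc(OC(F)(F)F)cc1)c1nnnn1CCOC(=O)NCCCCO`, shares the core of compound 2 and differs from it only in the aromatic group: 4-(trifluoromethoxy)phenyl in place of 2,3-dichlorophenyl on a saturated chain carbon bound to an oxygen on a saturated carbon.

Two comparisons bear on this change. First, a 2.6-fold lower number from compound 1 to compound 2 (0.42 log units; beyond the scatter), showing that adding a second chlorine to the ring helped modestly. Second, compound 3, which carries two trifluoromethyl groups on the ring, gives a much higher number than compound 2, so a heavily fluorinated ring does not go along with the lowest numbers here. Compound 4 removes both chlorines and brings in a fluorinated group at a different part of the ring, so a step to a higher number is expected in this assay, estimated as a 13-fold higher number from compound 2 to compound 4 (1.12 log units; beyond the scatter). Compound 4 is therefore expected to give about 8 nM, with a likely range from 2 nM to 40 nM.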

Compound 4, half-maximal effective concentration: 33.2 nM
For compound 4 the middle estimate is 4.2-fold (0.62 log units) below the measured one; the range from low to high includes it.
By their numbers in this assay, from the lowest: compound 2; then compound 1; then compounds 4 and 3 (each within the scatter of the next).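

In this assay this swap at the saturated chain carbon is costly: it gives a 54-fold higher number from compound 2 to compound 4 (1.74 log units; beyond the scatter), and the loss stays large against the ring with a single chlorine, at a 21-fold higher number from compound 1 to compound 4 (1.32 log units; beyond the scatter). Both steps dwarf the modest gain of a 2.6-fold lower number from compound 1 to compound 2 (0.42 log units; beyond the scatter), so the choice of aromatic group here can matter far more than one added chlorine suggested. The high number also no longer rests on a single ring type: compound 4 gives 33.2 nM and compound 3 gives 34 nM, within the scatter of each other, so one trifluoromethoxy group goes with the same poor level as two trifluoromethyl groups.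

This swap removes both chlorines and brings in the new group in one move, so the compounds shown cannot say which part accounts for the loss, and a plain unsubstituted phenyl ring or a ring carrying a methoxy group in place of trifluoromethoxy would help to separate the two. Nothing given here explains why the step is so large.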